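Working notes on the carbonyl substituent series

A few compounds are considered here, and "the series" means these few. Any claim that something is new, unique, unknown or untested is made for them only; others in the source may bear on it.

Measured in a physicochemical assay for solubility, at pH 7.4; on this read-out higher numbers stand for higher solubility and lower numbers for lower solubility:
- Compound 1 `CC(=O)N1CCc2c(C)c3c(n2-c2ccc(C(N)=O)c(c2)N[C@@H](C)[C@H](C)C1)CC(C)(C)CC3=O`: 38 ug/mL
- Compound 2 `Cc1c2c(n3c1CCN(C(=O)C(C)(C)N)C[C@@H](C)[C@H](C)Nc1cc-3ccc1C(N)=O)CC(C)(C)CC2=O`: > 100 ug/mL

Compound 2 stands at > 100 ug/mL, which is a limit of the assay and not a number. Its true position is therefore open, and it can serve only as a bound.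

Compound 3 `Cc1c2c(n3c1CCN(C(=O)[C@H](C)O)C[C@@H](C)[C@H](C)Nc1cc-3ccc1C(N)=O)CC(C)(C)CC2=O` differs from compound 2 on a carbonyl carbon: 1-hydroxyethyl in place of 1-amino-1-methylethyl on a carbonyl carbon. In short, 1-hydroxyethyl stands in place of 1-amino-1-methylethyl.

For the measured compounds named here, one measured step bears on this place: an at least 2.6-fold higher number from compound 1 to compound 2 (0.42 log units; beyond the scatter), with 1-amino-1-methylethyl in place of methyl. That is a different exchange at the same carbonyl carbon, so it guides the expectation only loosely. Since compound 3 also replaces the methyl of compound 1 at 38 ug/mL with a larger group, it is expected to sit nearer compound 2 in this assay. A small downward change is expected, estimated as an at least 1.4-fold lower number from compound 2 to compound 3 (0.15 log units; that floor lies within the scatter). A reading at the limit remains possible. For compound 3 the estimated value is 70 ug/mL, with an expected range of 30 ug/mL to 200 ug/mL.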

Compound 3, solubility: 60 ug/mL
For compound 3 the middle estimate is 1.2-fold (0.07 log units) above the measured one, and the stated range covers the measured number.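

Compound 3 gives this carbonyl carbon a second substituent larger than methyl with a measured number in this assay, and it separates less clearly from methyl than 1-amino-1-methylethyl does: the exchange of methyl for 1-hydroxyethyl reads as a 1.6-fold higher number from compound 1 to compound 3 (0.20 log units; within the scatter), so compound 1 and compound 3 are not told apart here. Replacing 1-amino-1-methylethyl with 1-hydroxyethyl reads as an at least 1.6-fold lower number from compound 2 to compound 3 (0.22 log units; that floor lies within the scatter), and with that floor inside the scatter, this exchange is not shown to lower the number at all. Compound 2 stands at > 100 ug/mL, which is a limit and not a number, and the step from it has only a floor because its value is such a limit: the limit of > 100 ug/mL in this assay, at which 1 of the 3 values shown sits.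

On these data alone, the true distance between compound 2 and compound 3 therefore stays open, as does whether the nitrogen or the branching of 1-amino-1-methylethyl carries its step from methyl. Also open, as far as these compounds go, is how a carboxylic acid, a longer chain ending in a hydroxyl group, or the opposite configuration of 1-hydroxyethyl would read on this carbonyl carbon in this assay.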